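The compounds below may be only part of what the source reports. "The series", "measured", "known", "first", "only" and "open" are said of these compounds alone.

Compound 1 `O=C1C=COC(/C=C/c2ccccc2)C1` gives 124 uM in a functional assay on HT-29 cells (Homo sapiens) for inhibition, read by sulforhodamine B assay, with a stated time of 48 h; on this read-out lower numbers stand for stronger inhibition of growth and higher numbers for weaker inhibition of growth.
Compound 2 `O=C1C=COC(/C=C/c2ccc(C(F)(F)F)cc2)C1` gives 33.3 uM in this assay.
Compound 3 `O=C1C=CCC(/C=C/c2ccccc2)N1` gives 1200 uM in this assay.

Compound 4 `O=C1C=CCC(/C=C/c2ccc(C(F)(F)F)cc2)N1` has not yet been measured. Going from compound 1 to compound 2, the change is trifluoromethyl in place of hydrogen on an aromatic carbon, and it made a 3.7-fold lower number from compound 1 to compound 2 (0.57 log units; beyond the scatter). Compound 3 carries a different core from compound 1; how the two cores differ is not broken down here, and compound 3 stands highest of the three measured numbers. Compound 4 arises from compound 3 by trifluoromethyl in place of hydrogen on an aromatic carbon, the same change at the same place. A step of similar size is expected in this assay, namely a 3.4-fold lower number from compound 3 to compound 4 (0.54 log units; beyond the scatter), because the earlier example made a 3.7-fold lower number from compound 1 to compound 2 (0.57 log units; beyond the scatter), though it rests on that single pair. Compound 4 is therefore expected to give about 350 uM, likely between 120 uM and 1000 uM.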

Compound 4, concentration for growth inhibition (reported as GI): 139 uM
Estimate against measurement, compound 4: 2.5-fold (0.40 log units) above; the measured number falls inside the stated range.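

In this assay, trifluoromethyl in place of hydrogen on an aromatic carbon gave an 8.6-fold lower number from compound 3 to compound 4 (0.94 log units; beyond the scatter) and so lowered the number on the second core as it had on the first. Set side by side, the two steps cannot be told apart in size: the same change on two cores in this assay, a 3.7-fold lower number (0.57 log units; beyond the scatter) from compound 1 to compound 2 and an 8.6-fold lower number (0.94 log units; beyond the scatter) from compound 3 to compound 4, 2.3-fold (0.37 log units) apart, within the scatter of two such steps. The change therefore carried over between these two cores, but two pairs cannot show that it would do so on any other core, and they do not explain why the number falls.

The compounds shown leave open whether another group in the same place, such as chlorine, a methoxy group or an amine, would lower the number too. They also leave open whether trifluoromethyl would have the same effect elsewhere on the aromatic ring.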